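Methoxy for Nitro at the Amide End: Estimating Compound 4

The source may report more compounds than this note shows. Statements on the series, on what has been measured and on what is new or still open speak of the compounds shown alone.

Measured compounds:
- compound 1 `Cc1ccc(S(=O)(=O)NCc2ccc(CNC(=O)c3ccc([N+](=O)[O-])cc3)cc2)cc1`: in an assay on MDA-MB-231 cells for binding affinity to C-X-C chemokine receptor type 4 (Homo sapiens), read by immunofluorescence and microscopy, with stated times of 10 min and 30 min (on this read-out lower numbers stand for an effect already at smaller amounts and higher numbers for an effect only at larger amounts of compound), compound 1 gives 10 nM
- compound 2 `COc1ccc(C(=O)NCc2ccc(CNS(=O)(=O)c3ccc(C)cc3)cc2)cc1`: compound 2 gives 100 nM
- compound 3 `O=C(NCc1ccc(CNS(=O)(=O)c2ccccc2)cc1)c1ccc([N+](=O)[O-])cc1`: compound 3 gives 100 nM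

Compound 3 gives the same number as compound 2 at the digits shown, and both stand higher than compound 1, which is the only one of the three with the lowest value in this assay. Compound 4 `COc1cccc(C(=O)NCc2ccc(CNS(=O)(=O)c3ccccc3)cc2)c1` is the next step from compound 3. The change is 3-methoxyphenyl in place of 4-nitrophenyl on a carbonyl carbon.

Among the measured compounds shown here, two measured steps bear on this. The step from compound 1 to compound 2 swapped the nitro for a methoxy at the same end of the molecule, and it gave a 10-fold higher number from compound 1 to compound 2 (1.00 log units; beyond the scatter). The step from compound 1 to compound 3 changed the other end, with a 10-fold higher number from compound 1 to compound 3 (1.00 log units; beyond the scatter). For the measured compounds named here, no measured pair shows a methoxy at the position it takes in compound 4, so the closest guide is the methoxy-for-nitro swap between compound 1 and compound 2.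

For compound 4 the expected step is therefore a 10-fold higher number from compound 3 to compound 4 (1.00 log units; beyond the scatter), a higher number, because the swap in compound 2 gave a 10-fold higher number from compound 1 to compound 2 (1.00 log units; beyond the scatter). The estimated value for compound 4 is 1000 nM, with a range from 300 nM to 3000 nM.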

Compound 4, effective concentration (reported as EC, without a stated level of effect): > 1000 nM
Compound 4 ended at the assay's limit; the forecaster's own chance of this, stated with the estimate: 10%; the middle value lies on the limit itself.
By their numbers in this assay, from the lowest: compound 1; then compounds 2 and 3 (each within the scatter of the next). At a limit, above all of these: compound 4.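

Compound 4 gives > 1000 nM in this assay, which is a limit of the assay and not a number: the limit of > 1000 nM in this assay, at which 1 of the 4 values shown sits.

The change on the carbonyl carbon brings an at least 10-fold higher number from compound 3 to compound 4 (1.00 log units; beyond the scatter), so replacing 4-nitrophenyl raises the number here too, in a compound without the methyl group that compound 1 carries. Among the compounds shown here, until now, the only measured step away from the nitro group was a 10-fold higher number from compound 1 to compound 2 (1.00 log units; beyond the scatter), so the two steps together show the same direction with and without that methyl group, and the 4-nitrophenyl group is the better of the groups tried at this place in both pairs.

On these data alone, because compound 4 sits at a limit, the size of its step stays unknown, and it cannot be compared with the earlier step; nor can the loss of the nitro group be separated from the different placement of the methoxy group, since the two arrive together in this single change. The compounds shown also leave open whether a different group on this ring, such as a nitrile, an amine or a carboxylic acid, would keep the number near that of compound 1 at 10 nM.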